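The source may report more compounds than this note shows. Statements on the series, on what has been measured and on what is new or still open speak of the compounds shown alone.

For the measured compounds named here, in a functional assay on IMR-32 cells (Homo sapiens) for cytotoxicity, read by sulforhodamine B assay, with a stated time of 48 h (on this read-out higher numbers stand for weaker inhibition and lower numbers for stronger inhibition), compound 1 `C=CCOc1ccc(F)cc1C(=O)c1cccnc1` gives 91000 nM as the highest of the three numbers measured so far. Compound 2 `O=C(c1cccnc1)c1cc(F)ccc1O` gives 6210 nM and compound 3 `O=C(c1cccnc1)c1cc(Cl)ccc1O` gives 19500 nM as lower numbers, each lying beyond the scatter from compound 1. Compound 4 `C=CCOc1ccc(Br)cc1C(=O)c1cccnc1` has not yet been measured. It differs from compound 1 by a single exchange (bromo in place of fluoro on an aromatic carbon) with bromo in place of fluoro on an aromatic carbon, para to an allyloxy group. The large step (a 15-fold lower number from compound 1 to compound 2 (1.17 log units; beyond the scatter)) with hydrogen in place of allyl on an oxygen does not apply directly, since compound 4 keeps the allyl. Closer is the modest step (a 3.1-fold higher number from compound 2 to compound 3 (0.50 log units; beyond the scatter)) with chloro in place of fluoro on an aromatic carbon. Going by the values given here, that step was seen with hydrogen rather than allyl on the oxygen, and no bromo compound has a number yet, so it carries over only loosely. On the evidence of that step (a 3.1-fold higher number from compound 2 to compound 3 (0.50 log units; beyond the scatter)) a modest move to a higher number is expected in this assay with wide uncertainty. For compound 4 the estimated value is 120000 nM with an expected range from 35000 nM to 350000 nM in this read-out. That would be an expected change (a 1.3-fold higher number from compound 1 to compound 4 (0.12 log units; within the scatter)) of modest size.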

Compound 4, half-maximal inhibitory concentration: 88000 nM
Estimate against measurement, compound 4: 1.4-fold (0.13 log units) above; measured number inside the range.
By their numbers in this assay, from the lowest: compound 2; then compound 3; then compounds 4 and 1 (each within the scatter of the next).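

In this assay, bromo in place of fluoro on the aromatic carbon para to an allyloxy group gives a 1.0-fold lower number from compound 1 to compound 4 (0.01 log units; within the scatter) and so, with the allyl kept on the oxygen, the two halogens cannot be told apart at this position. The earlier halogen exchange, a 3.1-fold higher number from compound 2 to compound 3 (0.50 log units; beyond the scatter), lay beyond the scatter, but it put chloro rather than bromo in place of fluoro and had hydrogen rather than allyl on the oxygen, so the two steps differ in more than one respect and do not show whether the group on the oxygen changes how this position responds. Nothing shown here offers an explanation for this result.

The compounds shown leave open whether bromo would give a number close to that of fluoro or of chloro with hydrogen on the oxygen, and so whether the large gain seen on removing the allyl holds with another halogen. They also leave open whether an amine or a methoxy group at this carbon, or a longer chain in place of the allyl, would move the number in this cell assay.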